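Notes on the series: from compound 3 to compound 4

The source may hold more compounds than are shown below. What is called first, only, known or untested is meant among the compounds shown, and "the series" means these compounds.

Three members of the series have been run in a functional assay on HEL cells (Homo sapiens); a higher number here means that more compound is tolerated, a lower number that less compound is tolerated. Compound 2 `O=C1c2ccccc2NS(=O)(=O)N1COCCO` gives 160 ug/mL in this assay. Compound 3 `C#CCOCN1C(=O)c2ccccc2NS1(=O)=O` gives 169 ug/mL in this assay, and the move from compound 2 to compound 3 is a 1.1-fold higher number from compound 2 to compound 3 (0.02 log units; within the scatter). Compound 1 `O=C1c2ccccc2N(Cc2ccccc2)S(=O)(=O)N1COCc1ccccc1` is reported only as a limit of this assay, > 40 ug/mL, so it yields no number to compare; the point is recorded as the limit of > 40 ug/mL in this assay, at which 1 of the 3 values shown sits. Compound 3 therefore stands at the highest of the two numbers available, with compound 2 within the scatter of it.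

Going by the values given here, compound 4 `O=C1c2ccccc2NS(=O)(=O)N1COCc1ccccc1` is the next target. phenyl in place of ethynyl on a saturated chain carbon bound to an oxygen on a saturated carbon The only measured step at this position, that from compound 2 to compound 3, was a 1.1-fold higher number from compound 2 to compound 3 (0.02 log units; within the scatter), which gives no sign that substitution at the chain carbon bound to the oxygen moves the read-out. Compound 1, which also carries a benzyl on that chain, sits at a limit and cannot inform the size. On this basis compound 4 is expected to stay close to compound 3, with an estimated 1.1-fold lower number from compound 3 to compound 4 (0.05 log units; within the scatter). The estimate for compound 4 in this assay is 150 ug/mL, within 55 ug/mL to 400 ug/mL.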

Compound 4, half-maximal cytotoxic concentration: 148 ug/mL
Compound 4: the middle estimate sits 1.0-fold (0.01 log units) above what was measured; measured number inside the range.
By their numbers in this assay, from the lowest: compounds 4, 2 and 3 (each within the scatter of the next).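

In this assay, phenyl in place of ethynyl on a saturated chain carbon bound to an oxygen on a saturated carbon gives a 1.1-fold lower number from compound 3 to compound 4 (0.06 log units; within the scatter), and phenyl in place of hydroxymethyl at the same place gives a 1.1-fold lower number from compound 2 to compound 4 (0.03 log units; within the scatter). The earlier compounds shown here with a number offered only the exchange of hydroxymethyl for ethynyl, neither of which holds a ring, whereas these steps show that a six-membered aromatic ring of carbon only, with its larger count of heavy atoms, also leaves the half-maximal cytotoxic concentration within the scatter when the sulfonamide nitrogen carries hydrogen. The step for hydrogen in place of benzyl on that sulfonamide nitrogen in a ring cannot be read, because compound 1 is recorded only as a limit: the limit of > 40 ug/mL in this assay, at which 1 of the 4 values shown sits.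

Still open, going by these compounds, is whether a group that brings a charge-bearing atom to this chain carbon, such as an amine or a carboxylic acid, would stay as close to compound 4 in this assay. A 4-chlorophenyl group or a longer chain ending in phenyl at the same place also remains untested among the compounds shown, as does the size of any effect of benzyl on the sulfonamide nitrogen.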